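Hydroxamic acid series: aminomethyl substitution and cellular inhibition

A few compounds are considered here, and "the series" means these few. Any claim that something is new, unique, unknown or untested is made for them only; others in the source may bear on it.

Measured so far in a functional assay on MCF7 cells (Homo sapiens) for inhibition; on this read-out higher numbers stand for weaker inhibition and lower numbers for stronger inhibition:
- compound 1, `O=C(NO)c1ccc(-c2ccc(CNc3ccccc3)cn2)s1`, gives 370 nM
- compound 2, `O=C(NO)c1ccc(-c2ccc(CNCc3ccc(-c4ccccc4)cc3)cn2)s1`, gives 150 nM
- compound 3, `O=C(NO)c1ccc(-c2cccc(CNCc3ccccc3)n2)s1`, gives 1900 nM

Compound 2 holds the lowest number of the three in this assay. Its nearest neighbour is compound 1, whose value lies beyond the scatter of compound 2, and compound 3 stands furthest away, also beyond the scatter. Going by the values given here, no pair among the measured compounds differs in only one place, so no single step can be read from them; the three values only show that the benzylamine-bearing members span a wide spread.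

The next compound, compound 4, `O=C(NO)c1ccc(-c2ccc(CNCc3ccc(Cl)cc3)cn2)s1`, is compared with compound 2 as the reference. The change is chloro in place of phenyl on an aromatic carbon. The larger aromatic substituent is thus exchanged for a single chlorine on the same aromatic carbon.

Among the compounds with values here, with no measured step of this kind available, the expectation rests on compound 2 alone. The step of a 1.9-fold higher number from compound 2 to compound 4 (0.27 log units; within the scatter) is expected to be a modest loss of potency, perhaps at the edge of the scatter rather than clearly beyond it. Compound 4 is therefore estimated at 280 nM, with a range from 100 nM to 800 nM.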

Compound 4, half-maximal inhibitory concentration: 130 nM
Compound 4: middle estimate off by 2.2-fold (0.33 log units), on the high side, and the stated range covers the measured number.
By their numbers in this assay, from the lowest: compounds 4 and 2 (each within the scatter of the next); then compound 1; then compound 3.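

Working notes: in this assay the phenyl on this aromatic carbon can give way to a single chloro with no change that can be read (the step is a 1.2-fold lower number from compound 2 to compound 4 (0.06 log units; within the scatter)), so the value of compound 2 does not depend on that second aromatic ring being present. The amine nitrogen now has its first readable step, with 4-chlorobenzyl in place of phenyl (the step is a 2.8-fold lower number from compound 1 to compound 4 (0.45 log units; beyond the scatter)), which lies beyond the scatter but is modest in size. Nothing at hand accounts for either step.

Open, from the compounds shown here alone, is whether the flat result at this aromatic carbon extends to other groups there, such as methoxy, a carboxylic acid or an amine, or whether chloro and phenyl simply happen to coincide. Also open, going by these compounds, is how a plain benzyl on the core of compound 2, or a longer chain between the amine nitrogen and the aromatic ring, would read against these values, since the step from compound 1 changes the whole group on that nitrogen at once.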